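The source may report more compounds than this note shows. Statements on the series, on what has been measured and on what is new or still open speak of the compounds shown alone.

Compound 2 `CSc1nc2ccccn2c(=N)c1S(=O)(=O)c1ccc(C(C)(C)C)cc1` stands highest of the two numbers in an assay on HeLa cells for displacement of a labelled ligand from 5-hydroxytryptamine receptor 6 (Homo sapiens) (on this read-out lower numbers stand for stronger inhibition and higher numbers for weaker inhibition), where compound 2 gives 65 nM; nearest is compound 1 `CSc1nc2ccccn2c(=N)c1S(=O)(=O)c1ccc(F)cc1`, which in this assay gives 22 nM. Among the measured compounds shown here, the single measured step, a 3.0-fold higher number from compound 1 to compound 2 (0.47 log units; beyond the scatter), came from tert-butyl in place of fluoro on an aromatic carbon. Compound 3 `CSc1nc2ccccn2c(=N)c1S(=O)(=O)c1ccc(OC(F)(F)F)cc1` carries the change (trifluoromethoxy in place of tert-butyl on an aromatic carbon). For the measured compounds named here, no measured step matches this exchange; the one step known only shows that exchanging the group on this aromatic carbon moved the number modestly. A modest downward step is therefore expected, a 1.6-fold lower number from compound 2 to compound 3 (0.21 log units; within the scatter). Compound 3 is estimated at 40 nM, with a range from 15 nM to 110 nM.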

Compound 3, half-maximal inhibitory concentration: 420 nM
The estimate for compound 3 lay 11-fold (1.02 log units) below the measured number, outside the stated range (above it).
By their numbers in this assay, from the lowest: compound 1; then compound 2; then compound 3.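

In this assay, the group on this aromatic carbon matters more than the first exchange suggested: trifluoromethoxy in place of tert-butyl gives a 6.5-fold higher number from compound 2 to compound 3 (0.81 log units; beyond the scatter), and trifluoromethoxy in place of fluoro gives a 19-fold higher number from compound 1 to compound 3 (1.28 log units; beyond the scatter). Trifluoromethoxy therefore gives the weakest inhibition of the three, and two groups with similar heavy-atom counts can still differ clearly. Nothing available explains this difference. Still open, as far as these compounds go, is how a methoxy group, a chlorine atom or an amine at this carbon would compare with fluoro. From the compounds shown here alone, whether any group could give stronger inhibition than fluoro also remains unknown.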